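Swapping the pyridine ring for a chlorinated phenol

A few compounds are considered here, and "the series" means these few. Any claim that something is new, unique, unknown or untested is made for them only; others in the source may bear on it.

Two chalcone-like compounds that share one core have been tested for their ability to slow the growth of human colon cancer cells. Compound 1 `COc1ccc(C(=O)/C=C/c2ccc(Br)cc2)c2c1C=CC(C)(C)O2` carries a 4-bromophenyl group on the double-bonded chain. In a functional assay on HT-29 cells (Homo sapiens) for antiproliferative activity, read by MTT assay, with a stated time of 24 h (on this read-out lower numbers stand for stronger inhibition and higher numbers for weaker inhibition), compound 1 reaches only the limit of the assay, > 10000 nM, so no number is known for it. Among the measured compounds shown here, compound 2 `COc1ccc(C(=O)/C=C/c2ccccn2)c2c1C=CC(C)(C)O2` has a pyridin-2-yl group in the same place, and in this assay compound 2 gives 2120 nM; this is the only actual number among the two values. The move an at least 4.7-fold lower number from compound 1 to compound 2 (0.67 log units; beyond the scatter) shows that the ring at this position matters.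

Compound 3 `COc1ccc(C(=O)/C=C/c2cc(Cl)ccc2O)c2c1C=CC(C)(C)O2` changes that ring again: 5-chloro-2-hydroxyphenyl in place of pyridin-2-yl on a double-bonded chain carbon bound to a double-bonded chain carbon. For the measured compounds named here, the new group brings back a carbon-only ring bearing a halogen, which in compound 1 went with the limit (the limit of > 10000 nM in this assay, at which 1 of the 2 values shown sits), yet it also adds a hydroxyl group that compound 1 lacks, so the only measured step gives mixed guidance. A somewhat higher number than that of compound 2 is therefore expected, estimated as a 2.4-fold higher number from compound 2 to compound 3 (0.37 log units; beyond the scatter). In this assay compound 3 is expected to give about 5000 nM, with a likely range from 1500 nM to 20000 nM.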

Compound 3, half-maximal inhibitory concentration: 4970 nM
For compound 3 the middle estimate is 1.0-fold (0.00 log units) above the measured one; measured number inside the range.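

In this assay, 5-chloro-2-hydroxyphenyl gives a less favourable result than pyridin-2-yl at this place on the chain, with a 2.3-fold higher number from compound 2 to compound 3 (0.37 log units; beyond the scatter), so pyridin-2-yl keeps the lower number of the two compounds that have real numbers. Even so, compound 3 shows that a carbon-only ring bearing a halogen does not always end at the limit of the assay, since it has a number of its own. Going by these compounds, compound 1 has a limit and not a number, so the step to compound 3 gives only a floor, an at least 2.0-fold lower number from compound 1 to compound 3 (0.30 log units; that floor lies within the scatter), and their true distance stays unknown: the limit of > 10000 nM in this assay, at which 1 of the 3 values shown sits.

The hydroxyl group and the chlorine enter together in compound 3, so the compounds shown do not separate what each one contributes to its value. A phenyl ring carrying only a hydroxyl group, only a chlorine, or an amine or a carboxylic acid in their place would help to show which groups on this ring go with lower numbers.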